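Swapping the Aryl Group of Compound 1

The source may hold more compounds than are shown below. What is called first, only, known or untested is meant among the compounds shown, and "the series" means these compounds.

Measured so far, in a functional assay on B16-F10 cells (Mus musculus) for inhibition, read by MTT assay, with a stated time of 72 h; on this read-out higher numbers stand for weaker inhibition and lower numbers for stronger inhibition:
compound 1 `CC(C)c1ccc(-c2nc(SCc3cn(CC(=O)NC(=O)Nc4ccccn4)nn3)nc(Nc3cccc(C(F)(F)F)c3)c2C#N)cc1` — compound 1 gives 1700 nM
compound 2 `CC(C)c1ccc(-c2nc(SCc3cn(CC(=O)NC(=O)Nc4ccccn4)nn3)nc(Nc3ccccc3)c2C#N)cc1` — compound 2 gives 14300 nM
compound 3 `COc1ccccc1Nc1nc(SCc2cn(CC(=O)NC(=O)Nc3ccccn3)nn2)nc(-c2ccc(C(C)C)cc2)c1C#N` — compound 3 gives 34600 nM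

Compound 1 holds the lowest number of the three. The step of an 8.4-fold higher number from compound 1 to compound 2 (0.92 log units; beyond the scatter) comes with hydrogen in place of trifluoromethyl on an aromatic carbon, and the step of a 20-fold higher number from compound 1 to compound 3 (1.31 log units; beyond the scatter) with 2-methoxyphenyl in place of 3-(trifluoromethyl)phenyl on a nitrogen on an aromatic ring; between those two, a 2.4-fold higher number from compound 2 to compound 3 (0.38 log units; beyond the scatter) comes with methoxy in place of hydrogen on an aromatic carbon.

Compound 4 `COc1cc(-c2nc(SCc3cn(CC(=O)NC(=O)Nc4ccccn4)nn3)nc(Nc3cccc(C(F)(F)F)c3)c2C#N)cc(OC)c1OC` keeps the 3-(trifluoromethyl)phenyl amino group of compound 1 and differs from it by 3,4,5-trimethoxyphenyl in place of 4-isopropylphenyl on an aromatic carbon. Among the measured compounds shown here, none of the measured steps touches this position: all three vary the group on the nitrogen, and all three raise the number. They bear on the change from compound 1 to compound 4 only in showing that the shared core tolerates little change without loss, so the expectation is loose. Compound 4 is estimated to give 3000 nM, within a wide range from 500 nM to 20000 nM. That estimate means an expected step of a 1.8-fold higher number from compound 1 to compound 4 (0.25 log units; within the scatter) in this assay, with no strong ground for either direction.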

Compound 4, half-maximal inhibitory concentration: 24400 nM
Estimate against measurement, compound 4: 8.1-fold (0.91 log units) below, outside the stated range (above it).
By their numbers in this assay, from the lowest: compound 1; then compounds 2, 4 and 3 (each within the scatter of the next, the first and the last beyond it).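

Until this point, every measured step had changed the group on the nitrogen, so the aryl group on the aromatic carbon opposite the ring nitrogen had not been tested. In this assay, the change at this position gives a 14-fold higher number from compound 1 to compound 4 (1.16 log units; beyond the scatter), showing that this aryl group also strongly affects the read-out, even with the 3-(trifluoromethyl)phenyl amino group kept in place. The swap brings in hydrogen-bond acceptors and a larger group, but nothing available explains why the number rises, and no measurement bears on the cause of the loss.

With only 4-isopropylphenyl and 3,4,5-trimethoxyphenyl shown at this position, a single step cannot separate the loss of the isopropyl group from the arrival of the methoxy groups. As far as these compounds go, a plain phenyl, a 4-methoxyphenyl or a 4-tert-butylphenyl on this carbon would help to separate them, and whether the same step holds with the phenylamino group of compound 2 or the 2-methoxyphenyl amino group of compound 3 also stays open.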